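The compounds below may be only part of what the source reports. "The series", "measured", "known", "first", "only" and "open" are said of these compounds alone.

In a toxicity assay on L02 cells (Homo sapiens) for cytotoxicity, read by MTT assay, with a stated time of 72 h (a lower number here means a stronger inhibitor, a higher number a weaker inhibitor), the measured compounds are:
- compound 1 `O=C1c2c[n+]([O-])c3ccccc3c2C(=O)c2c1c1ccccc1n2Cc1cn(CC(O)CO)nn1`: 1070 nM
- compound 2 `CCCCN1CCN(CCCCn2c3c(c4ccccc42)C(=O)c2c[n+]([O-])c4ccccc4c2C3=O)CC1`: 5690 nM
- compound 3 `O=C1c2c[n+]([O-])c3ccccc3c2C(=O)c2c1c1ccccc1n2CCN1CCCCC1`: 1050 nM

Compound 3 stands at the low end of these numbers, but it is not separated from the other low value. Compound 4 `O=C1c2c[n+]([O-])c3ccccc3c2C(=O)c2c1c1ccccc1n2CCCN1CCC(O)CC1` differs from it in the side chain: (4-hydroxypiperidin-1-yl)methyl in place of piperidin-1-yl on a saturated chain carbon, two bonds along the chain from an aromatic nitrogen. In words, (4-hydroxypiperidin-1-yl)methyl stands in place of piperidin-1-yl on a saturated chain carbon, two bonds along the chain from an aromatic nitrogen.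

Going by the values given here, two measured steps bear on this change, and both alter the side chain. One is a 1.0-fold lower number from compound 1 to compound 3 (0.01 log units; within the scatter), which shows that a different side chain need not move the number. The other is a 5.4-fold lower number from compound 2 to compound 3 (0.73 log units; beyond the scatter), which shows that such a change can move it modestly. A small rise in this assay is therefore expected, smaller than the second step and possibly not beyond the scatter.

The estimated change is a 1.3-fold higher number from compound 3 to compound 4 (0.12 log units; within the scatter).

For compound 4, the estimated value is 1400 nM, with an expected range of 550 nM to 3500 nM.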

Compound 4, half-maximal inhibitory concentration: 120 nM
Beside the measured number, compound 4's estimate is 12-fold (1.07 log units) above it; the measured number lies below the stated range.
By their numbers in this assay, from the lowest: compound 4; then compounds 3 and 1 (each within the scatter of the next); then compound 2.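

In this assay the change from 2-(piperidin-1-yl)ethyl to 3-(4-hydroxypiperidin-1-yl)propyl gives an 8.8-fold lower number from compound 3 to compound 4 (0.94 log units; beyond the scatter) and so shows that this position can carry a change that lowers the number beyond the scatter, which the earlier low pair did not show. Compound 4 also stands apart from the other two compounds, with an 8.9-fold lower number from compound 1 to compound 4 (0.95 log units; beyond the scatter) and a 47-fold lower number from compound 2 to compound 4 (1.68 log units; beyond the scatter) as its remaining steps. It therefore has the lowest number of the four, with all of its steps beyond the scatter.

The compounds shown leave open whether the drop goes with the propyl chain or the hydroxy group, a question that 3-(piperidin-1-yl)propyl or 2-(4-hydroxypiperidin-1-yl)ethyl on the same core would address. No measurement given here accounts for the drop.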